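Amide aryl variation in a flavonol series: compound 4

This account rests on a few compounds, and the source may have more. Where it says the series, first, only, none or still open, it means among the compounds named here.

Measured so far in a functional assay on GTL 16 cells for antiproliferative activity against GTL 16 cell line (Homo sapiens), read by CCK-8 assay, with a stated time of 72 h; a higher number here means a weaker inhibitor, a lower number a stronger inhibitor:
compound 1 `COc1ccc(C(=O)Nc2cccc(-c3oc4cc(-c5ccc(F)cc5)ccc4c(=O)c3O)c2)cc1` gives 21100 nM;
compound 2 `O=C(Nc1cccc(-c2oc3cc(-c4ccc(F)cc4)ccc3c(=O)c2O)c1)c1ccc(F)cc1F` gives 9640 nM;
compound 3 `CCc1ccc(C(=O)Nc2cccc(-c3oc4cc(-c5ccc(F)cc5)ccc4c(=O)c3O)c2)cc1` gives 24600 nM.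

Compound 3 carries the highest number of the three. Its nearest neighbour is compound 1, and the two are within the scatter of each other: a 1.2-fold higher number from compound 1 to compound 3 (0.07 log units; within the scatter). The step from the difluorinated amide aryl is larger: a 2.6-fold higher number from compound 2 to compound 3 (0.41 log units; beyond the scatter).

Compound 4 `Cc1cc(C(=O)Nc2cccc(-c3oc4cc(-c5ccc(F)cc5)ccc4c(=O)c3O)c2)ccc1F` is the next member. The change from compound 3 reads (4-fluoro-3-methylphenyl in place of 4-ethylphenyl on a carbonyl carbon). Within the data shown here, two measured steps bear on it. Replacing a para-substituted hydrocarbon aryl with a fluorinated aryl on the carbonyl carbon gave a 2.2-fold lower number from compound 1 to compound 2 (0.34 log units; beyond the scatter), and the reverse direction gave a 2.6-fold higher number from compound 2 to compound 3 (0.41 log units; beyond the scatter). Both put the fluorinated amide aryl at a modestly lower number. The entering group keeps a methyl, so the step is expected to be smaller than either of these and perhaps within the scatter; the expected step is a 1.6-fold lower number from compound 3 to compound 4 (0.21 log units; within the scatter).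

The estimate for compound 4 in this assay is 15000 nM, with a range from 6000 nM to 38000 nM.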

Compound 4, half-maximal inhibitory concentration: 12100 nM
Estimate against measurement, compound 4: 1.2-fold (0.09 log units) above, and the stated range covers the measured number.
By their numbers in this assay, from the lowest: compounds 2, 4, 1 and 3 (each within the scatter of the next, the first and the last beyond it).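

In this assay, the 4-fluoro-3-methylphenyl group separates from 4-ethylphenyl, a 2.0-fold lower number from compound 3 to compound 4 (0.31 log units; beyond the scatter), so an amide aryl that keeps a methyl and carries a single fluorine still shows a lower number than the ethyl analogue. It does not separate from the other two amide aryls, a 1.3-fold higher number from compound 2 to compound 4 (0.10 log units; within the scatter) and a 1.7-fold lower number from compound 1 to compound 4 (0.24 log units; within the scatter), even though the 2,4-difluorophenyl and 4-methoxyphenyl groups do differ from each other beyond the scatter. No measurement at hand bears on why the number moves with this change.

An amide aryl carrying the fluorine alone or the methyl alone would show how each contributes to the step from 4-ethylphenyl. Also open, from the compounds shown here alone, is how a carboxylic acid or a dimethylamino group on this aryl would read in this assay.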